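Swapping the pyridine ring for a methylpyrimidine

The source may hold more compounds than are shown below. What is called first, only, known or untested is meant among the compounds shown, and "the series" means these compounds.

This study measures compounds in an assay on T-REx-293 cells for inhibition of potassium channel subfamily T member 1 (Homo sapiens), read by patch clamp; on this read-out lower numbers stand for stronger inhibition and higher numbers for weaker inhibition. Of the compounds shown here, two have been measured so far. Compound 1 `C[C@H](NC(=O)c1cc(C(F)(F)F)nn1C)c1nc(-c2cccc(F)c2)no1` gives 136 nM, while compound 2 `C[C@H](NC(=O)c1cc(C(F)(F)F)nn1C)c1nc(-c2cccnc2)no1` gives 11800 nM. Within the data shown here, the only measured step, an 87-fold higher number from compound 1 to compound 2 (1.94 log units; beyond the scatter), came from replacing a 3-fluorophenyl group with a pyridin-3-yl group. Compound 2 therefore stands at the highest number of the two, meaning the weaker inhibition of the pair.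

Compound 3 `Cc1cc(-c2noc([C@H](C)NC(=O)c3cc(C(F)(F)F)nn3C)n2)ncn1` has not yet been measured. It differs from compound 2 by 6-methylpyrimidin-4-yl in place of pyridin-3-yl on an aromatic carbon. Among the measured compounds shown here, no measured step covers this kind of change. The step from compound 1 to compound 2 bears on it only loosely, since it shows that the six-membered ring attached to the shared core matters a great deal in this assay and that exchanging a carbon for a nitrogen there moved the number a long way upward. With a further nitrogen entering along with a methyl group, the direction cannot be read from the data with confidence. Compound 3 is therefore expected to stay near compound 2, with a 1.3-fold higher number from compound 2 to compound 3 (0.10 log units; within the scatter) anticipated within the scatter, and its estimated value in this assay is 15000 nM, with a range from 3500 nM to 60000 nM.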

Compound 3, half-maximal inhibitory concentration: 1410 nM
Estimate against measurement, compound 3: 11-fold (1.03 log units) above; measured number outside the range, below it.
By their numbers in this assay, from the lowest: compound 1; then compound 3; then compound 2.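

In this assay, the step of an 8.4-fold lower number from compound 2 to compound 3 (0.92 log units; beyond the scatter) shows that a nitrogen-containing ring on this aromatic carbon need not cost as much as compound 2 suggested, since 6-methylpyrimidin-4-yl wins back part of what pyridin-3-yl lost. The recovery is only partial: the step of a 10-fold higher number from compound 1 to compound 3 (1.02 log units; beyond the scatter) leaves 3-fluorophenyl with the lowest number of the three groups tried at this position. Among these three compounds, the number therefore does not simply climb as ring nitrogen atoms are added, and compound 3, with 2 ring nitrogen atoms, goes against that simple reading by sitting lower than compound 2, with 1.

No measurement shown here explains why the six-membered ring has such a large effect on this read-out. The change from compound 2 to compound 3 also alters the ring nitrogen atoms and adds a methyl group in one move, so it remains open which of the two accounts for the lower number, a question that a plain pyrimidin-4-yl group, lacking the methyl, could help to separate.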